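This account rests on a few compounds, and the source may have more. Where it says the series, first, only, none or still open, it means among the compounds named here.

Measured compounds in a functional assay on RAW264.7 cells (Mus musculus) for inhibition, read by Griess assay, with stated times of 2 h and 24 h; on this read-out lower numbers stand for stronger inhibition and higher numbers for weaker inhibition:
- compound 1 `CCn1cc(COc2cc(O)c3c(c2)O[C@H](c2ccc(OC)c(O)c2)CC3=O)nn1`: 15000 nM
- compound 2 `COc1ccc([C@@H]2CC(=O)c3c(O)cc(OCc4cn(C5CCCCC5)nn4)cc3O2)cc1O`: 15600 nM
- compound 3 `COc1ccc([C@@H]2CC(=O)c3c(O)cc(OCc4cn(C5CCC5)nn4)cc3O2)cc1O`: 15300 nM

Compound 3 stands second highest of these three numbers; its nearest neighbour is compound 2 and its furthest is compound 1, and both gaps lie within the scatter. Compound 4 `COc1ccc([C@@H]2CC(=O)c3c(O)cc(OCc4cn(Cc5ccccc5C)nn4)cc3O2)cc1O` differs from compound 3 by 2-methylbenzyl in place of cyclobutyl on an aromatic nitrogen. Going by the values given here, the steps that bear on this are the earlier exchanges of the group on the same aromatic nitrogen: a 1.0-fold higher number from compound 1 to compound 3 (0.01 log units; within the scatter), a 1.0-fold lower number from compound 2 to compound 3 (0.01 log units; within the scatter) and a 1.0-fold higher number from compound 1 to compound 2 (0.02 log units; within the scatter). Ethyl, cyclobutyl and cyclohexyl at that position gave numbers within the scatter of one another. The 2-methylbenzyl group is a bigger change than any measured step covers, so nothing beyond the scatter is expected, with wide uncertainty. The expected step is a 1.0-fold lower number from compound 3 to compound 4 (0.01 log units; within the scatter). Compound 4 is therefore estimated at 15000 nM, with a range from 7000 nM to 32000 nM.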

Compound 4, half-maximal inhibitory concentration: 13100 nM
Compound 4: middle estimate off by 1.1-fold (0.06 log units), on the high side; the range from low to high includes it.
By their numbers in this assay, from the lowest: compounds 4, 1, 3 and 2 (each within the scatter of the next).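

In this assay the step to an aromatic group on this nitrogen stays within the scatter (a 1.2-fold lower number from compound 3 to compound 4 (0.07 log units; within the scatter)), as do the exchanges of cyclohexyl (a 1.2-fold lower number from compound 2 to compound 4 (0.08 log units; within the scatter)) and of the ethyl methyl (a 1.1-fold lower number from compound 1 to compound 4 (0.06 log units; within the scatter)). The position on the aromatic nitrogen therefore takes 2-methylbenzyl, with its six-membered aromatic ring of carbon only, as well as the ethyl, cyclobutyl and cyclohexyl groups, with no step beyond the scatter. Nothing available explains this flatness. Going by these compounds, whether an amine or a carboxylic acid on this nitrogen would give a step beyond the scatter stays open.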